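Swapping the aryl group on the isoxazoline ring

The compounds below may be only part of what the source reports. "The series", "measured", "known", "first", "only" and "open" are said of these compounds alone.

The compounds here share one core and differ only in the aryl group attached to a carbon with a double bond to nitrogen. Compound 1 `C[C@H]1CC[C@@H]2[C@@H](OC(=O)[C@]23CC(c2c(Cl)cccc2Cl)=NO3)[C@]2(C)C(=O)C=C[C@@]12O` carries a 2,6-dichlorophenyl group and, in a physicochemical assay for lipophilicity (on this read-out lower numbers stand for lower lipophilicity and higher numbers for higher lipophilicity), compound 1 gives 2.67. Compound 2 `COc1ccc(C2=NO[C@]3(C2)C(=O)O[C@@H]2[C@H]3CC[C@H](C)[C@]3(O)C=CC(=O)[C@@]23C)cc1` carries a 4-methoxyphenyl group, and in this assay compound 2 gives 1.47. Compound 3 `C[C@H]1CC[C@@H]2[C@@H](OC(=O)[C@]23CC(c2cccc([N+](=O)[O-])c2)=NO3)[C@]2(C)C(=O)C=C[C@@]12O` carries a 3-nitrophenyl group, and in this assay compound 3 gives 1.37. Compound 2 thus lies far under compound 1, with a drop of a number 1.20 log units lower from compound 1 to compound 2 (beyond the scatter), while the step of a number 0.10 log units lower from compound 2 to compound 3 (within the scatter) lies within the scatter, so compound 2 and compound 3 cannot be told apart.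

Compound 4 `Cc1cccc(C2=NO[C@]3(C2)C(=O)O[C@@H]2[C@H]3CC[C@H](C)[C@]3(O)C=CC(=O)[C@@]23C)c1` is not yet measured. Compared with compound 2 it changes as follows: 3-methylphenyl in place of 4-methoxyphenyl on a carbon with a double bond to nitrogen. Going by the values given here, no measured step involves a methyl group, so the two large drops from compound 1 say little here; the step from compound 2 to compound 3 shows that swapping one substituted phenyl for another can leave the number nearly unchanged. A small rise is expected, as a number 0.43 log units higher from compound 2 to compound 4 (beyond the scatter). Compound 4 is therefore estimated at 1.9, within 1.4 to 2.5.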

Compound 4, partition coefficient: 1.86
The estimate for compound 4 lay 0.04 log units above the measured number; the measured number falls inside the stated range.
By their numbers in this assay, from the lowest: compounds 3 and 2 (each within the scatter of the next); then compound 4; then compound 1.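

In this assay, going by these compounds alone, the earlier compounds showed two substituted phenyl groups at this carbon that could not be told apart, whereas 3-methylphenyl stands clear of both, with a number 0.39 log units higher from compound 2 to compound 4 (beyond the scatter) and with a number 0.49 log units higher from compound 3 to compound 4 (beyond the scatter) for methyl in place of nitro on an aromatic carbon. The 2,6-dichlorophenyl group still gives the highest number of the four, with a number 0.81 log units lower from compound 1 to compound 4 (beyond the scatter) for the change to 3-methylphenyl, so compound 4 falls between the other compounds rather than joining either end. Nothing shown here explains these differences.

Going by these compounds, all four compounds carry a substituted phenyl group at this carbon, so the reading for plain phenyl remains open. Also open, on these data alone, is where a phenyl bearing an amine, a carboxylic acid or a longer alkyl chain would fall in this assay.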